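From Carbamoyl to Methyl on a Ring Nitrogen

The compounds below may be only part of what the source reports. "The series", "measured", "known", "first", "only" and "open" are said of these compounds alone.

Compounds measured in an ADME assay on microsomes from liver (Rattus norvegicus) for metabolic stability, read by LC-MS, with a stated time of 10 min, tested at 0.5 uM; on this read-out higher numbers stand for a more stable compound and lower numbers for a less stable compound:
- compound 1 `CC(C)N1CCN(CCCN(C[C@H]2Cc3ccccc3CN2)[C@H]2CCCc3cccnc32)CC1`: 4%
- compound 2 `CCN1CCN(CCCN(C[C@H]2Cc3ccccc3CN2)[C@H]2CCCc3cccnc32)CC1`: 1%
- compound 3 `NC(=O)N1CCN(CCCN(C[C@H]2Cc3ccccc3CN2)[C@H]2CCCc3cccnc32)CC1`: 4%

Compound 3 gives 4% in this assay, level with compound 1 at the digits shown, and all three values lie within the scatter of one another. The next structure, compound 4 `CN1CCN(CCCN(C[C@H]2Cc3ccccc3CN2)[C@H]2CCCc3cccnc32)CC1`, keeps the shared core and carries methyl in place of carbamoyl on an amine nitrogen in a ring.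

Among the compounds with values here, three measured steps bear on this change. Two alter the group at the same nitrogen: no change at the digits printed from compound 1 to compound 3 (within the scatter) and a number 3 percentage points higher from compound 2 to compound 3 (within the scatter). The third, a number 3 percentage points lower from compound 1 to compound 2 (within the scatter), links the isopropyl and ethyl compounds. None of the three goes beyond the scatter, so across isopropyl, ethyl and carbamoyl the group at this nitrogen has left the number essentially unmoved. Within the data shown here, no measured compound yet carries methyl there, so this remains an inference from its three neighbours.

The expected result in this assay is no change beyond the scatter, with an estimated a number 1 percentage points lower from compound 3 to compound 4 (within the scatter). Compound 4 is expected at 3%, with an estimated range from 1% to 8%.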

Compound 4, percent of the compound remaining: 10%
Beside the measured number, compound 4's estimate is 7 percentage points below it; the measured number lies above the stated range.
By their numbers in this assay, from the lowest: compounds 2, 1, 3 and 4 (each within the scatter of the next).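

In this assay methyl in place of carbamoyl on the ring nitrogen gives a number 6 percentage points higher from compound 3 to compound 4 (within the scatter) and methyl in place of isopropyl gives a number 6 percentage points higher from compound 1 to compound 4 (within the scatter) while the ethyl compound set against the methyl compound gives a number 9 percentage points higher from compound 2 to compound 4 (within the scatter) as its step. A fourth group at this nitrogen, with a single heavy atom, therefore still does not separate from the others, and no pair among these four compounds is set apart, even at the largest of these steps. No measurement offered here gives a reason for these numbers.

Still open, from the compounds shown here alone, is whether a bare hydrogen on this nitrogen, a chain ending in a carboxylic acid or a longer chain would give a step beyond the scatter. Equally open, going by these compounds, is whether a change elsewhere on the shared core would move the number more than any group at this nitrogen has.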